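This account rests on a few compounds, and the source may have more. Where it says the series, first, only, none or still open, it means among the compounds named here.

Compound 1 `C#CCn1c(=O)c(C=O)cc2cc(F)ccc21` and compound 2 `C#CCn1c(=O)c(C=O)cc2cc(C)ccc21` share a small core; compound 3 `C#CCn1c(=O)c(/C=C/C(=O)/C=C(O)/C=C/c2ccc(O)c(OC)c2)cc2cc(C)ccc21` carries the core of compound 2 with a long extension, and compound 4 `C#CCn1c(=O)c(/C=C/C(=O)/C=C(O)/C=C/c2ccc(O)c(OC)c2)cc2cc(F)ccc21` is its not-yet-measured counterpart. In a functional assay on A549 cells (Homo sapiens) for cytotoxicity, read by MTT assay, with a stated time of 24 h (a higher number here means a weaker inhibitor, a lower number a stronger inhibitor), compound 1 gives > 100000 nM, which is a limit of the assay rather than a number. Compound 2 likewise reaches only a limit, > 100000 nM. The change fluoro in place of methyl on an aromatic carbon thus yields a step that the two limits leave unreadable from compound 2 to compound 1. Among the measured compounds shown here, compound 3 gives 23900 nM, the only number among the three; how its core differs from that of compound 2 is not broken down here. The same change, (fluoro in place of methyl on an aromatic carbon), is made from compound 3 to compound 4. Because the limit of > 100000 nM in this assay, at which 2 of the 3 values shown sit, hides the size of the earlier step, the expectation for compound 4 rests on compound 3 alone, with 23900 nM, and is an estimated 1.3-fold higher number from compound 3 to compound 4 (0.10 log units; within the scatter). Compound 4 is therefore expected to give 30000 nM, likely between 10000 nM and 100000 nM.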

Compound 4, half-maximal inhibitory concentration: 40500 nM
Estimate against measurement, compound 4: 1.4-fold (0.13 log units) below, within the range that was stated.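

In this assay, putting fluoro in place of methyl on an aromatic carbon of the core with the long extension gives a 1.7-fold higher number from compound 3 to compound 4 (0.23 log units; within the scatter), so on this core the two groups cannot be told apart. This is a single readable pair, and it does not show that the change would behave the same way on any other core. The same change on the small core cannot be read, so the two cores cannot be compared, because the small-core values give no size for the step: the limit of > 100000 nM in this assay, at which 2 of the 4 values shown sit.

The compounds shown leave open whether another group in the same place, such as chloro or an amine, would shift the number beyond the scatter. They also leave open how a shorter chain in place of the long extension would read.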